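Branching the imidazole substituent: from ethyl to isopropyl

A few compounds are considered here, and "the series" means these few. Any claim that something is new, unique, unknown or untested is made for them only; others in the source may bear on it.

Compound 1 `c1ccc(C(CCN2CCCCC2)c2ccccc2)cc1`: 69.6 nM
Compound 2 `NC(=O)C(CCn1ccnc1)(c1ccccc1)c1ccccc1`: 5.07 nM
Compound 3 `CCc1nccn1CCC(C(N)=O)(c1ccccc1)c1ccccc1`: 78.1 nM

Of the compounds shown here, three have been measured in an assay on ileum with muscarinic acetylcholine receptor M3 (Cavia porcellus) as the target; a higher number here means a weaker inhibitor, a lower number a stronger inhibitor. Compound 2 gives the lowest number, 5.07 nM. Compound 3 stands at the top of the three with 78.1 nM, close to compound 1, whose value of 69.6 nM lies within the scatter of it, and far from compound 2. Among the compounds with values here, the one step that bears on the new compound is a 15-fold higher number from compound 2 to compound 3 (1.19 log units; beyond the scatter), a large move toward weaker inhibition when an ethyl group is introduced on the imidazole.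

Compound 4 `CC(C)c1nccn1CCC(C(N)=O)(c1ccccc1)c1ccccc1` carries the change (methyl in place of hydrogen on a saturated chain carbon bound to an aromatic carbon and a saturated chain carbon); cut one bond further out, this reads ethyl to isopropyl. Within the data shown here, since the only measured step on this substituent, from compound 2 to compound 3, pointed toward a higher number, a further increase in bulk at the same place is expected to continue in that direction, though more modestly. For compound 4 the step of a 2.0-fold higher number from compound 3 to compound 4 (0.31 log units; beyond the scatter) is therefore expected, and the estimate is 160 nM, with a range from 50 nM to 500 nM.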

Compound 4, antagonist equilibrium constant: 1.8 nM
Compound 4: the middle estimate sits 89-fold (1.95 log units) above what was measured, and the stated range ends above it.
By their numbers in this assay, from the lowest: compound 4; then compound 2; then compounds 1 and 3 (each within the scatter of the next).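

In this assay the step from ethyl to isopropyl is a 43-fold lower number from compound 3 to compound 4 (1.64 log units; beyond the scatter) and so runs against a 15-fold higher number from compound 2 to compound 3 (1.19 log units; beyond the scatter) on the same substituent. Isopropyl also goes past hydrogen, with a 2.8-fold lower number from compound 2 to compound 4 (0.45 log units; beyond the scatter) at this end of the series, so hydrogen, ethyl and isopropyl do not line up in the order of their carbon count. A single methyl on a saturated chain carbon bound to an aromatic carbon and a saturated chain carbon is thus enough to reverse the direction of change, and nothing at hand explains that reversal. 

From the compounds shown here alone, whether a methyl, cyclopropyl or tert-butyl group would side with ethyl or with isopropyl stays open, so it cannot yet be said which of the two is the exception. Also open, going by these compounds, is whether the effect of isopropyl holds once the carboxamide gives way to a carboxylic acid or a nitrile.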